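From naphthalen-1-yl to 4-chlorophenyl on a saturated chain carbon

This account rests on a few compounds, and the source may have more. Where it says the series, first, only, none or still open, it means among the compounds named here.

Compound 1 `N#C/C(=C\c1ccccc1OS(=O)(=O)c1ccc([N+](=O)[O-])cc1)C(=O)Nc1nnc(Cc2cccc3ccccc23)s1`: 18%
Compound 2 `N#C/C(=C\c1ccccc1OS(=O)(=O)c1ccc(Cl)cc1)C(=O)Nc1nnc(Cc2cccc3ccccc23)s1`: 15%
Compound 3 `N#C/C(=C\c1ccccc1OS(=O)(=O)c1ccc(F)cc1)C(=O)Nc1nnc(Cc2cccc3ccccc23)s1`: 12%

All three values come from a functional assay on HL-60 cells (Homo sapiens) for inhibition, read by CCK-8 assay, with a stated time of 48 h, tested at 20 uM; a lower number here means less inhibition of growth, a higher number more inhibition of growth at the concentration tested. Compound 2 reads 15%, and its gaps to the other two are small: a number 3 percentage points lower from compound 1 to compound 2 (within the scatter) and a number 3 percentage points lower from compound 2 to compound 3 (within the scatter). Numbers this close cannot be ranked, so compound 2 stands with the other two in a single group. The widest gap in the set is a number 6 percentage points lower from compound 1 to compound 3 (within the scatter).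

Compound 4 `N#C/C(=C\c1ccccc1OS(=O)(=O)c1ccc(Cl)cc1)C(=O)Nc1nnc(Cc2ccc(Cl)cc2)s1` differs from compound 2 in one group: 4-chlorophenyl in place of naphthalen-1-yl on a saturated chain carbon bound to an aromatic carbon. In words, this is 4-chlorophenyl in place of naphthalen-1-yl on a saturated chain carbon bound to an aromatic carbon. The measured steps bear on this only loosely. Each swaps nitro, chloro or fluoro on an aromatic carbon, so none of them tests the place that changes here. For the measured compounds named here, they show only that these three compounds sit close together in this assay. With no direct evidence for this swap, no step beyond the scatter is expected, although the uncertainty is wide and leans towards more inhibition. The expected step is a number 2 percentage points higher from compound 2 to compound 4 (within the scatter). For compound 4 the estimated value is 17%, with an expected range from 6% to 38%.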

Compound 4, percent growth inhibition at one concentration: 15%
Estimate against measurement, compound 4: 2 percentage points above, within the range that was stated.
By their numbers in this assay, from the lowest: compounds 3, 2, 4 and 1 (each within the scatter of the next).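

For the compounds shown here, until now, the only changes seen were swaps among nitro, chloro and fluoro on an aromatic carbon, so the saturated chain carbon bound to an aromatic carbon had not been tested. In this assay, replacing naphthalen-1-yl with 4-chlorophenyl at that place gives no change at the digits printed from compound 2 to compound 4 (within the scatter), which means that going from two six-membered aromatic rings to one, with a chlorine added, leaves the reading indistinguishable from that of compound 2. No separate measurement on these compounds offers an explanation for this result, and the step alone cannot show which feature of either group matters.

Going by these compounds, this comparison is a single swap made with the chloro group held in place, so it remains open whether the same swap would read alike alongside the nitro or fluoro group. On these data alone, it is also open whether a quite different group on this carbon, such as an amine, a carboxylic acid or a longer chain in place of 4-chlorophenyl, would move the reading beyond the usual scatter.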